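Replacing Nitro with Amino on an Inactive Sulfone Amide

This account rests on a few compounds, and the source may have more. Where it says the series, first, only, none or still open, it means among the compounds named here.

Of the compounds shown here, two have been tested in a functional assay on T47D cells (Homo sapiens) for cytotoxicity, read by MTT assay, with a stated time of 72 h; a lower number here means a stronger inhibitor of growth, a higher number a weaker inhibitor of growth. Compound 1 `COc1ccc(CS(=O)(=O)CC(=O)Nc2c(C)cc(C)cc2C)cc1[N+](=O)[O-]` gives > 30000 nM, which is a limit of the assay rather than a number. Compound 2 `COc1ccc(CS(=O)(=O)CC(=O)Nc2ccccc2)cc1[N+](=O)[O-]` gives > 30000 nM, again only a limit. The step that the two limits leave unreadable from compound 1 to compound 2 therefore cannot be sized, and compound 2 stands only at the limit, as described by the limit of > 30000 nM in this assay, at which 2 of the 2 values shown sit.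

Compound 3 `COc1ccc(CS(=O)(=O)CC(=O)Nc2ccccc2)cc1N` is the next compound, unmeasured so far. It differs from compound 2 by amino in place of nitro on an aromatic carbon. Among the compounds with values here, no measured step bears on this change, since the only step between the measured compounds, a step that the two limits leave unreadable from compound 1 to compound 2, concerns the amide nitrogen and is unreadable. With no readable step to build on, the expectation for compound 3 rests on compound 2 sitting at > 30000 nM. Compound 3 is therefore estimated at 30000 nM (range 8000 nM to 100000 nM), an expected step of a number no higher from compound 2 to compound 3 (the limit leaves the size open).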

Compound 3, concentration for 50% growth inhibition: > 30000 nM
Compound 3 gave a limit, no number; the forecaster's own chance of this, stated with the estimate: 70%; the middle value lies on the limit itself.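

Compound 2 and compound 3 each give only a limit of the assay, not a number, so the step between them, amino in place of nitro, cannot be read: the limit of > 30000 nM in this assay, at which 3 of the 3 values shown sit.

The compounds shown leave open how large that swap's effect is, and whether any change to the shared core gives a measurable value.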